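The compounds below may be only part of what the source reports. "The series", "measured", "known", "first", "only" and "open" are said of these compounds alone.

Working notes on the series. Three compounds on the shared core carry numbers in a functional assay on L1210 cells (Mus musculus), with a stated time of 1 days; a higher number here means a more potent compound, by a factor of ten per unit of this negative logarithm, a lower number a less potent compound. Compound 2 `CC1=C(N2CC2)C(=O)C(CCCOC(N)=O)=C(N2CC2)C1=O` gives 5.48 and stands highest of the three. Compound 1 `CCCC1=C(N2CC2)C(=O)C(C(COC(N)=O)OC)=C(N2CC2)C1=O` gives 4.64, and compound 3 `CCCC1=C(N2CC2)C(=O)C(CCC)=C(N2CC2)C1=O` gives 4.14; both sit beyond the scatter below compound 2. Among the measured compounds shown here, the one measured step that touches a single change is a number 0.50 log units lower from compound 1 to compound 3 (beyond the scatter), where a group of 3 heavy atoms (3 carbon; no ring) takes the place of a group of 8 heavy atoms (4 carbon, 1 nitrogen, 3 oxygen; no ring) on a double-bonded ring carbon.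

Compound 4 `CC1=C(N2CC2)C(=O)C(N2CC2)=C(N2CC2)C1=O` is not yet measured. It differs from compound 2 in one place: a group of 3 heavy atoms (2 carbon, 1 nitrogen; one three-membered non-aromatic ring with 1 hetero atom) in place of a group of 7 heavy atoms (4 carbon, 1 nitrogen, 2 oxygen; no ring), on a double-bonded ring carbon. For the measured compounds named here, this is a comparable loss of the chain bearing a hydrogen-bond donor and acceptors, so the step from compound 1 to compound 3 is the only one bearing on it; a decrease of modest size is expected, though the entering three-membered ring has no measured precedent here. Compound 4 is expected to give 5, within 4.3 to 5.7, meaning an expected step of a number 0.48 log units lower from compound 2 to compound 4 (beyond the scatter).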

Compound 4, logarithm of the reciprocal of the active concentration, log(1/C): 5.69
Compound 4: the middle estimate sits 0.69 log units below what was measured; measured number inside the range.
By their numbers in this assay, from the lowest: compound 3; then compound 1; then compounds 2 and 4 (each within the scatter of the next).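

In this assay the exchange on this double-bonded ring carbon gives a number 0.21 log units higher from compound 2 to compound 4 (within the scatter), so compound 2 and compound 4 cannot be told apart on this read-out. The chain of 7 heavy atoms, with its hydrogen-bond donor, is therefore not needed at this position to hold the number, since aziridin-1-yl in its place, with 0 hydrogen-bond donors, does as well. Among the compounds shown here, this differs from the only other step at this position, a number 0.50 log units lower from compound 1 to compound 3 (beyond the scatter), where a group of 3 heavy atoms without a ring takes the place of the larger chain. No measurement here gives a reason for this result.

Open, going by these compounds, is whether a plain ethyl group or an amine at this position would keep the number on the same core. Also open, on these data alone, is whether a second aziridin-1-yl group would hold up on the core of compound 1.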